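The compounds below may be only part of what the source reports. "The series", "measured", "known", "first", "only" and "open" are said of these compounds alone.

Measured in an assay on mitochondria from L6 cells (Rattus norvegicus) for activation, with a stated time of 90 min; on this read-out higher numbers stand for an effect only at larger amounts of compound and lower numbers for an effect already at smaller amounts:

- compound 1, `CC(=O)c1ccc(Nc2nc3nonc3nc2O)cc1`: 93700 nM
- compound 2, `Oc1nc2nonc2nc1Nc1ccc(C(F)(F)F)cc1`: 10400 nM

For the measured compounds named here, only two compounds have been measured so far, and compound 2 has the lower of the two numbers, that is, it acts already at the smaller amount. Going by the values given here, the single measured step separating them, a 9.0-fold lower number from compound 1 to compound 2 (0.95 log units; beyond the scatter), comes from swapping trifluoromethyl in for acetyl on an aromatic carbon of the outer ring; the shared core is otherwise unchanged.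

Compound 3, `Oc1nc2nonc2nc1Nc1ccc(OC(F)(F)Cl)cc1`, keeps that core and the same attachment of the outer ring, but differs from compound 2 at one place: chloro(difluoro)methoxy in place of trifluoromethyl on an aromatic carbon. Among the compounds with values here, no measured pair varies this particular group, so the one known step, which concerns acetyl against trifluoromethyl, does not bear directly on this change. With nothing in the data pointing in either direction, the expectation for this assay is a step no larger than the usual scatter, a 1.2-fold lower number from compound 2 to compound 3 (0.06 log units; within the scatter). On that basis compound 3 is estimated at 9000 nM, within a range of 2500 nM to 32000 nM.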

Compound 3, half-maximal effective concentration: 1900 nM
Beside the measured number, compound 3's estimate is 4.7-fold (0.68 log units) above it; measured number below the stated range.
By their numbers in this assay, from the lowest: compound 3; then compound 2; then compound 1.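

In this assay, the group on the outer ring turns out to matter more than the first pair could show: putting chloro(difluoro)methoxy in place of trifluoromethyl gives a 5.5-fold lower number from compound 2 to compound 3 (0.74 log units; beyond the scatter). Until now, this position had offered only a comparison of acetyl with trifluoromethyl, and trifluoromethyl was the better of those two; the new group goes further, and the full span across the three compounds is a 49-fold lower number from compound 1 to compound 3 (1.69 log units; beyond the scatter). The new group brings an oxygen, which counts as a hydrogen-bond acceptor, and a chlorine in place of one fluorine, but no measurement shown here explains the gain.

Going by these compounds, it remains open which part of the change carries the step, the oxygen link or the chlorine, and a trifluoromethoxy group at this same place would help separate the two. Also open, on these data alone, is how far this position tolerates other kinds of group, such as an amine, a carboxylic acid or a longer chain ending in chlorine, and whether the step holds if the shared core itself is altered.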